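Thiophen-3-yl to Furan-2-yl on the Shared Core

A few compounds are considered here, and "the series" means these few. Any claim that something is new, unique, unknown or untested is made for them only; others in the source may bear on it.

Compound 1 `CC(C)OC(=O)C1=C(C(F)(F)F)NC(=O)NC1c1ccsc1` gives 23% in an assay on cells for displacement of a labelled ligand from adenosine receptor A1 (Homo sapiens), read by radioligand binding, with a stated time of 60 min, tested at 1 uM; a lower number here means less inhibition, a higher number more inhibition at the concentration tested (going by the name of the read-out).
Compound 2 `CCOC(=O)C1=C(C(F)(F)F)NC(=O)NC1c1ccsc1` gives 32% in this assay.
Compound 3 `CC1=C(C(=O)OC(C)C(F)(F)F)C(c2ccoc2)NC(=O)N1` gives 10%; 1% (2 entries) in this assay.

For the measured compounds named here, compound 1 and compound 2 give numbers within the scatter of each other, while the entries of compound 3, (the several entries of compound 3 in this assay, 10%; 1% (2 entries)), fall lower; compound 3 differs from compound 1 in more than one place, so no single step between them can be drawn. Going by the values given here, the one measured step, a number 9 percentage points higher from compound 1 to compound 2 (within the scatter), changes hydrogen in place of methyl on a saturated chain carbon bound to an oxygen next to a carbonyl group and a saturated chain carbon, and it stays within the scatter. The unmeasured compound 4 `CC(C)OC(=O)C1=C(C(F)(F)F)NC(=O)NC1c1ccco1` differs from compound 1 by furan-2-yl in place of thiophen-3-yl on a saturated ring carbon. Among the compounds with values here, no measured step touches this five-membered aromatic ring, so nothing here points in either direction. With no reason to expect a step beyond the scatter, compound 4 is estimated at 20%, between 5% and 38%. That estimate means an expected step of a number 3 percentage points lower from compound 1 to compound 4 (within the scatter).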

Compound 4, a percentage reported as inhibition, at one concentration (the size of the read-out at that concentration, not a potency): 11%
The estimate for compound 4 lay 9 percentage points above the measured number, and the stated range covers the measured number.
By their numbers in this assay, from the lowest: compound 4; then compounds 1 and 2 (each within the scatter of the next).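

In this assay, for the compounds shown here, placing furan-2-yl instead of thiophen-3-yl on the saturated ring carbon gives a number 12 percentage points lower from compound 1 to compound 4 (beyond the scatter), so this position responds to a change of ring, whereas the one earlier step, at the ester chain, stayed within the scatter. The two rings have the same count of heavy atoms and each carries one hetero atom, yet oxygen replaces sulfur and the ring is attached through a different ring carbon, and this single step cannot separate those two differences. Nothing shown here gives a measured cause for the drop.

Thiophen-2-yl and furan-3-yl on the core of compound 1 would tell these two differences apart, and a phenyl ring would show how the position responds to a six-membered aromatic ring. From the compounds shown here alone, whether the step holds with the ethyl ester of compound 2 also remains open.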